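A few compounds are considered here, and "the series" means these few. Any claim that something is new, unique, unknown or untested is made for them only; others in the source may bear on it.

In a functional assay on HeLa cells (Homo sapiens) for antiproliferative activity, with a stated time of 24 h (a higher number here means a weaker inhibitor, a lower number a stronger inhibitor), compound 1 (`NC(=O)c1c(NC(=O)c2ccccc2Cl)sc2c1CCN(Cc1ccccc1)C2`) gives 38400 nM and compound 2 (`NC(=O)c1c(NC(=O)c2ccccc2Cl)sc2c1CCN(C(=S)Nc1ccccc1F)C2`) gives 28700 nM, so compound 2 stands level with compound 1 within the scatter. Compound 3 (`Cc1ccccc1NC(=S)N1CCc2c(sc(NC(=O)c3ccccc3Cl)c2C(N)=O)C1`) differs from compound 2 by methyl in place of fluoro on an aromatic carbon, ortho to a large group. Among the compounds with values here, the only measured step, a 1.3-fold lower number from compound 1 to compound 2 (0.13 log units; within the scatter), exchanged a much larger group than this and still stayed small, so no change beyond the scatter is expected in this assay. The expected step is a 1.0-fold higher number from compound 2 to compound 3 (0.00 log units; within the scatter). Compound 3 is estimated at 29000 nM, with an expected range of 15000 nM to 55000 nM.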

Compound 3, half-maximal inhibitory concentration: > 50000 nM
Compound 3: only a limit was reported; the forecaster's own chance of this, stated with the estimate: 10%; at least 1.7-fold (0.23 log units) between middle value and limit.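

In this assay compound 3 gives only a limit, > 50000 nM, and not a number. Methyl in place of fluoro on the aromatic carbon gives an at least 1.7-fold higher number from compound 2 to compound 3 (0.24 log units; that floor lies within the scatter), and the whole group on the ring amine nitrogen gives an at least 1.3-fold higher number from compound 1 to compound 3 (0.11 log units; that floor lies within the scatter). So methyl at this place brings no visible gain over fluoro, while the true size of the step stays unknown and only its floor can be read: the limit of > 50000 nM in this assay, at which 1 of the 3 values shown sits.

As far as these compounds go, what a chloro, a methoxy or an amine on this aromatic carbon would give stays open.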